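The compounds below may be only part of what the source reports. "The series", "measured", "known", "first", "only" and "open" are said of these compounds alone.

In a functional assay on MCF7 cells (Homo sapiens) for antiproliferative activity, read by MTT assay, with a stated time of 72 h; on this read-out higher numbers stand for weaker inhibition and lower numbers for stronger inhibition:
- Compound 1 `O=C(N/N=C/c1cccc([N+](=O)[O-])c1)Nc1ccc(Oc2ccnc3[nH]ccc23)c(F)c1`: "not active" (no number reported)
- Compound 2 `O=C(N/N=C/c1ccc([N+](=O)[O-])cc1)Nc1ccc(Oc2ccnc3[nH]ccc23)c(F)c1`: 4000 nM

Going by the values given here, compound 2 holds the only number so far, so it cannot yet be ranked against another measured value. Compound 3 `O=C(N/N=C/c1ccc(O)c(Br)c1)Nc1ccc(Oc2ccnc3[nH]ccc23)c(F)c1` keeps the shared core and changes one group: 3-bromo-4-hydroxyphenyl in place of 4-nitrophenyl on a carbon with a double bond to nitrogen. Among the compounds with values here, no measured step shows what such a swap does, so no shift beyond the usual scatter is expected in this assay. The estimated change is a 1.3-fold lower number from compound 2 to compound 3 (0.12 log units; within the scatter). Compound 1 gives "not active" (no number reported), so a result without a number also remains possible. Compound 3 is expected at about 3000 nM, within an estimated range of 700 nM to 12000 nM.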

Compound 3, half-maximal inhibitory concentration: 8230 nM
Estimate against measurement, compound 3: 2.7-fold (0.44 log units) below, within the range that was stated.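

The step of a 2.1-fold higher number from compound 2 to compound 3 (0.31 log units; beyond the scatter) shows that the group on this carbon with a double bond to nitrogen can move the result in this assay modestly, just past the usual scatter. Replacing 4-nitrophenyl with 3-bromo-4-hydroxyphenyl weakens inhibition but still leaves a measurable number. No supporting measurement explains this shift. On these data alone, it remains open whether the bromine, the hydroxyl group or the loss of the nitro group drives the change, and how a phenyl ring carrying an amine or a carboxylic acid would behave here.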